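The compounds below may be only part of what the source reports. "The series", "measured", "known", "first", "only" and "open" are said of these compounds alone.

Of the compounds shown here, three sharing one core have been tested in a functional assay on A549 cells (Homo sapiens) for cytotoxicity, read by MTT assay, with a stated time of 72 h; on this read-out higher numbers stand for weaker inhibition and lower numbers for stronger inhibition. Compound 1 (`COc1cccc(/C=C2\CCC/C(=C\c3ccc(Br)cc3)C2=O)c1OC`) gives > 20000 nM, which is a limit and not a number. Compound 2 (`COc1ccccc1/C=C1\CCC/C(=C\c2cccc(OC)c2OC)C1=O`) gives > 20000 nM, again a limit. Among the measured compounds shown here, compound 3 (`COc1cccc(/C=C2\CCC/C(=C\c3cccc(OC)c3OC)C2=O)c1`) gives 16400 nM, the only actual number so far in this assay.

The measured steps all exchange one aromatic group for another. They comprise a step that the two limits leave unreadable from compound 1 to compound 2, then an at least 1.2-fold lower number from compound 1 to compound 3 (0.08 log units; that floor lies within the scatter), and finally an at least 1.2-fold lower number from compound 2 to compound 3 (0.08 log units; that floor lies within the scatter). The last two are only floors that lie within the scatter, so none of the three gives a readable size.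

The next compound is compound 4 (`COc1cccc(/C=C2\CCC/C(=C\c3cccc(O)c3)C2=O)c1OC`), which differs from compound 3 by hydrogen in place of methyl on an oxygen on an aromatic ring. This turns methoxy to hydroxy, or 3-methoxyphenyl to 3-hydroxyphenyl. For the measured compounds named here, no measured step makes this change, so the data offer no direct precedent for its size or direction. The expectation therefore stays anchored on compound 3 at 16400 nM, with no shift beyond the scatter foreseen. The expected outcome is a 1.3-fold lower number from compound 3 to compound 4 (0.10 log units; within the scatter), a small move with an uncertain direction. The estimated value for compound 4 is 13000 nM, with an expected range from 5000 nM to 20000 nM.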

Compound 4, half-maximal inhibitory concentration: > 20000 nM
Compound 4: only a limit was reported; the forecaster's own chance of this, stated with the estimate: 30%; middle value at least 1.5-fold (0.18 log units) from the limit.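

Among the compounds shown here, the exchange of methoxy for hydroxy, hydrogen in place of methyl on an oxygen on an aromatic ring, had no precedent among the earlier compounds, and in this assay it gives an at least 1.2-fold higher number from compound 3 to compound 4 (0.08 log units; that floor lies within the scatter). So the hydroxy group shows no sign of giving a lower number than the methoxy group it replaces, yet this floor is too small to establish a real loss either. The steps to compound 4 from compound 1 and compound 2 cannot be read, and the full size of the step from compound 3 stays hidden, because these readings run into a limit of the assay rather than a number: the limit of > 20000 nM in this assay, at which 3 of the 4 values shown sit.

Still open, on these data alone, is whether a different group on that oxygen, such as ethyl or a longer chain, or an amine on the ring in place of the hydroxy, would move the number clearly away from that of compound 3. Also open, as far as these compounds go, is whether the same exchange of methoxy for hydroxy on the other aromatic ring would give a readable step.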